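The source may report more compounds than this note shows. Statements on the series, on what has been measured and on what is new or still open speak of the compounds shown alone.

Compound 1 `CCCn1c(SCc2cc([N+](=O)[O-])ccc2OC)nc2cc(NC(=O)NC(C)(C)C)ccc21` carries propyl on the ring nitrogen of the shared core and in an assay on isolated protein for inhibition of Gonadotropin-releasing hormone receptor (Homo sapiens) (a higher number here means a weaker inhibitor, a lower number a stronger inhibitor), compound 1 gives 18 nM. Within the data shown here, compound 2 `COc1ccc([N+](=O)[O-])cc1CSc1nc2cc(NC(=O)NC(C)(C)C)ccc2n1Cc1ccncc1` instead bears (pyridin-4-yl)methyl there, and in this assay compound 2 gives 47 nM, the higher of the two numbers so far; the single measured step, a 2.6-fold higher number from compound 1 to compound 2 (0.42 log units; beyond the scatter), is modest but beyond the scatter.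

Compound 3 `COc1ccc([N+](=O)[O-])cc1CSc1nc2cc(NC(=O)NC(C)(C)C)ccc2n1C(C)C` is not yet measured. The change from compound 2 to compound 3 is isopropyl in place of (pyridin-4-yl)methyl on an aromatic nitrogen. Among the measured compounds shown here, this removes the ring that entered in the step from compound 1 to compound 2 and restores a small saturated group on the aromatic nitrogen, so the one relevant step, a 2.6-fold higher number from compound 1 to compound 2 (0.42 log units; beyond the scatter), is expected to be roughly reversed. For compound 3 in this assay the expectation is therefore a modest lower number, about a 2.1-fold lower number from compound 2 to compound 3 (0.33 log units; beyond the scatter), near the value of compound 1, estimated at 22 nM with a range from 9 nM to 55 nM.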

Compound 3, half-maximal inhibitory concentration: 62 nM
Compound 3: middle estimate off by 2.8-fold (0.45 log units), on the low side; measured number above the stated range.
By their numbers in this assay, from the lowest: compound 1; then compounds 2 and 3 (each within the scatter of the next).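

On the aromatic nitrogen, a large ring-bearing group and a small branched one cannot be told apart in this assay: a 1.3-fold higher number from compound 2 to compound 3 (0.12 log units; within the scatter). The clearer difference lies between the two small saturated groups, a 3.4-fold higher number from compound 1 to compound 3 (0.54 log units; beyond the scatter), so removing the (pyridin-4-yl)methyl ring does not in itself return the number to that of compound 1, and among these three groups only propyl stands apart. No available evidence bears on the difference between propyl and isopropyl at this position.

Still open, as far as these compounds go, is whether a longer chain such as butyl, or a chain ending in an amine, would match compound 1 at 18 nM or fall on either side of it. Also open, from the compounds shown here alone, is whether benzyl, with an all-carbon ring, would read like the (pyridin-4-yl)methyl of compound 2.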